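Ester to ketone: a lipophilicity step in a long-chain diene

A few compounds are considered here, and "the series" means these few. Any claim that something is new, unique, unknown or untested is made for them only; others in the source may bear on it.

Measured compounds:
compound 1, `CC#CCOC(=O)/C=C(C)/C=C/CC(C)CCCC(C)C` — 6.4
compound 2, `COC(C)(C)CCCC(C)C/C=C/C(C)=C/C(N)=O` — 3.52

Of the compounds shown here, two have been measured in a physicochemical assay for lipophilicity; on this read-out higher numbers stand for higher lipophilicity and lower numbers for lower lipophilicity. Compound 1, `CC#CCOC(=O)/C=C(C)/C=C/CC(C)CCCC(C)C`, gives 6.4, and compound 2, `COC(C)(C)CCCC(C)C/C=C/C(C)=C/C(N)=O`, gives 3.52. Of these two numbers compound 1 stands higher, and the gap between them lies beyond the usual scatter of the method.

The account now follows compound 1 to compound 3, `CC(/C=C/CC(C)CCCC(C)C)=C\C(=O)CC(C)C`, which has not yet been measured in this assay. The change is isobutyl in place of (but-2-yn-1-yl)oxy on a carbonyl carbon. Among the measured compounds shown here, no pair of measured compounds shows this particular change, so its size cannot be read from the data at hand; only the two values above inform the expectation.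

For compound 3 in this assay, the expected step of a number 0.30 log units higher from compound 1 to compound 3 (within the scatter) is a small one upward, roughly at the edge of the scatter, because compound 1 already sits at 6.4. Compound 3 is therefore estimated at 6.7, with a likely range from 6.1 to 7.3.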

Compound 3, partition coefficient: 7.22
Compound 3: the middle estimate sits 0.52 log units below what was measured; the range from low to high includes it.
By their numbers in this assay, from the lowest: compound 2; then compound 1; then compound 3.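

In this assay, among the compounds shown here, isobutyl in place of (but-2-yn-1-yl)oxy on a carbonyl carbon gives a number 0.82 log units higher from compound 1 to compound 3 (beyond the scatter), the first change at a single place that can be read. It shows that this carbonyl carbon is a place where the read-out can still move beyond the scatter, even starting from compound 1, which gives 6.4. The group that leaves carries an oxygen and a triple bond and isobutyl carries neither, so these features change together in one exchange, and no information at hand bears on the reason for the step.

The compounds shown leave open how far the read-out would move with other groups on the same carbonyl carbon, such as an amine, a tert-butyl group or a longer chain, and so which part of the exchange matters most. They also leave open whether the same exchange would give a step of similar size on a core other than that of compound 1.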